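The source may report more compounds than this note shows. Statements on the series, on what has been measured and on what is new or still open speak of the compounds shown alone.

Measured compounds:
compound 1 `CCN(Cc1c[nH]nn1)C(=O)COc1ccc(C)cc1` — 31100 nM
compound 2 `CCN(Cc1cccs1)C(=O)COc1ccc(C)cc1O` — 8 nM

Of the compounds shown here, two have been measured in an assay on HEK293 cells for agonist activity at transient receptor potential cation channel subfamily M member 8 (Homo sapiens), read by fluorescence and calcium flux, with a stated time of 15 min; on this read-out lower numbers stand for an effect already at smaller amounts and higher numbers for an effect only at larger amounts of compound. Compound 1 gives 31100 nM, the highest of the two numbers. Among the compounds with values here, compound 2 gives 8 nM, a far lower number, beyond the scatter; compound 2 differs from compound 1 in more than one place, so the two values show only that the pair spans a wide range, not what any single change does.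

Compound 3 `CCN(Cc1nccs1)C(=O)COc1ccc(C)cc1` has not yet been measured in this assay. It differs from compound 1 in one place: 1,3-thiazol-2-yl in place of 1H-1,2,3-triazol-4-yl on a saturated chain carbon bound to an amide-type nitrogen. Both rings have five members and carry two hydrogen-bond acceptors, but the hydrogen-bond donor of the triazole is gone and a sulfur enters in place of two nitrogens. Within the data shown here, with no measured pair that isolates this change, the size of its effect is open. Compound 3 is expected to give a somewhat lower number than compound 1, a step of a 10-fold lower number from compound 1 to compound 3 (1.02 log units; beyond the scatter), though the range is wide. The estimate for compound 3 in this assay is 3000 nM, expected to fall from 300 nM to 30000 nM.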

Compound 3, half-maximal effective concentration: 3060 nM
Compound 3: the middle estimate sits 1.0-fold (0.01 log units) below what was measured; measured number inside the range.
By their numbers in this assay, from the lowest: compound 2; then compound 3; then compound 1.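

Within this assay, compounds 1 and 3 provide the first comparison that isolates one change: replacing 1H-1,2,3-triazol-4-yl with 1,3-thiazol-2-yl on a saturated chain carbon bound to an amide-type nitrogen gives a 10-fold lower number from compound 1 to compound 3 (1.01 log units; beyond the scatter). With the rest of the molecule unchanged, the identity of this five-membered aromatic ring clearly affects the read-out. Several features change together, however: the hydrogen-bond donor is lost, a sulfur enters, and the ring goes from three hetero atoms to two, while the hydrogen-bond acceptor count stays the same, and nothing available gives a reason for the step.

The pair cannot separate these features, and it leaves open whether a 1-methyl-1,2,3-triazole, which would keep the three ring nitrogens without the ring hydrogen, or a six-membered ring such as phenyl or pyridine would give a higher or lower number at this place. Going by these compounds, compound 2 differs from compound 3 in more than one place, so the part of its much lower number that comes from any single difference also remains unknown.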